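Replacing nitro with methoxy on compound 2

This account rests on a few compounds, and the source may have more. Where it says the series, first, only, none or still open, it means among the compounds named here.

In a functional assay on MDA-MB-231 cells (Homo sapiens) for cytotoxicity, read by MTT assay, with a stated time of 72 h (on this read-out higher numbers stand for weaker inhibition and lower numbers for stronger inhibition), compound 1 (`Nn1c(SCc2ccccc2[N+](=O)[O-])nnc1-c1c[nH]c2ccccc12`) gives 9520 nM, compound 2 (`Nn1c(SCc2cccc([N+](=O)[O-])c2)nnc1-c1c[nH]c2ccccc12`) gives 310 nM and compound 3 (`Nn1c(SCc2ccc([N+](=O)[O-])cc2)nnc1-c1c[nH]c2ccccc12`) gives 740 nM. All three carry a nitro group on the same ring and differ only in where it sits. Compound 2 has the lowest number of the three, and its gaps to both others lie beyond the scatter: compound 3 stands nearest and compound 1 furthest.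

Compound 4 (`COc1cccc(CSc2nnc(-c3c[nH]c4ccccc34)n2N)c1`) changes the group rather than its place: methoxy in place of nitro on an aromatic carbon, meta to a large group. Among the compounds with values here, no measured compound yet carries anything other than nitro, so the series offers no direct reading of such a replacement. Within the data shown here, with compound 2 at 310 nM, the lowest of only three values, a moderate rise in the number is expected, with no large loss assumed. The expected change is a 2.9-fold higher number from compound 2 to compound 4 (0.46 log units; beyond the scatter). Compound 4 is estimated at 900 nM, with an expected range from 250 nM to 4000 nM.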

Compound 4, half-maximal inhibitory concentration: 15600 nM
The estimate for compound 4 lay 17-fold (1.24 log units) below the measured number, outside the stated range (above it).
By their numbers in this assay, from the lowest: compound 2; then compound 3; then compounds 1 and 4 (each within the scatter of the next).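

In this assay methoxy in place of nitro on an aromatic carbon, meta to a large group, produces a 50-fold higher number from compound 2 to compound 4 (1.70 log units; beyond the scatter) and so counts as a large step. The earlier compounds shown here varied only where the nitro sits, whereas this result shows that at this place the read-out also depends strongly on the group itself, with the rest of compound 2 kept. Nothing at hand says why the number rises so far.

Going by these compounds, it remains open whether another group at this place, such as an amine, a carboxylic acid or a nitrile, would keep the number close to that of compound 2. On these data alone, the size of the same replacement at the places the nitro holds in compound 1 and compound 3 also remains open.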